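A few compounds are considered here, and "the series" means these few. Any claim that something is new, unique, unknown or untested is made for them only; others in the source may bear on it.

Measured so far:
compound 1 `CC1(C)[C@H]2CC[C@]1(C)N(Cc1cn(-c3cccc(Cl)c3)nn1)C(=O)C2`: 260 nM
compound 2 `COc1ccccc1-n1cc(CN2C(=O)C[C@@H]3CC[C@@]2(C)C3(C)C)nn1`: 120 nM

In a functional assay on PANC-1 cells (Homo sapiens) for inhibition, read by MTT assay, with a stated time of 24 h (a higher number here means a weaker inhibitor, a lower number a stronger inhibitor), compound 1 gives the highest of these two numbers, and the step of a 2.2-fold lower number from compound 1 to compound 2 (0.34 log units; beyond the scatter) is the only one measured. Compound 3 `COc1cccc(-n2cc(CN3C(=O)C[C@@H]4CC[C@@]3(C)C4(C)C)nn2)c1` differs from compound 1 by methoxy in place of chloro on an aromatic carbon. That measured step also swapped a chloro-bearing ring for a methoxy-bearing one, so a similar modest drop in the number is expected here, though the new group sits in a different place and the step may fall within the scatter. Compound 3 is therefore expected to give 170 nM, within 80 nM to 400 nM. This estimate means a step of a 1.5-fold lower number from compound 1 to compound 3 (0.18 log units; within the scatter), expected to be small.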

Compound 3, half-maximal inhibitory concentration: 860 nM
Estimate against measurement, compound 3: 5.1-fold (0.70 log units) below; the whole stated range lies below it.
By their numbers in this assay, from the lowest: compound 2; then compound 1; then compound 3.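

On the ring of compound 1, methoxy in place of chloro is not an interchangeable swap: in this assay it gives a 3.3-fold higher number from compound 1 to compound 3 (0.52 log units; beyond the scatter). The place of the methoxy matters too, as 3-methoxyphenyl in place of 2-methoxyphenyl gives a 7.2-fold higher number from compound 2 to compound 3 (0.86 log units; beyond the scatter), so the lower number of compound 2 cannot be credited to having a methoxy group alone. No evidence at hand explains either step.

Still open, from the compounds shown here alone, is how an amine or a carboxylic acid in that same place on the ring would compare with chloro and methoxy.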